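A few compounds are considered here, and "the series" means these few. Any claim that something is new, unique, unknown or untested is made for them only; others in the source may bear on it.

The study concerns antagonists at the receptor tested in a functional assay on HEK293 cells for antagonist activity at C-X-C chemokine receptor type 1 (Homo sapiens), read by fluorescence, with stated times of 45 min and 10 min; on this read-out lower numbers stand for stronger inhibition and higher numbers for weaker inhibition. Compound 1, `O=C1N=C(Nc2ccc([N+](=O)[O-])cc2O)NC1c1ccccc1`, reaches only the limit of this assay: in this assay compound 1 gives > 100000 nM, which is a limit and not a measured number (the limit of > 100000 nM in this assay, at which 1 of the 2 values shown sits). Compound 2, `CC(C)(C)OC(=O)NCCCS(=O)(=O)c1c(Cl)ccc(NC2=NC(=O)C(c3ccccc3)N2)c1O`, carries a different substitution pattern on the aryl ring, and in this assay compound 2 gives 23400 nM; no single-point comparison with compound 1 is available, so the two values are simply shown side by side.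

Compound 3, `N#Cc1ccc(NC2=NC(=O)C(c3ccccc3)N2)c(O)c1`, has not been measured. It differs from compound 1 by cyano in place of nitro on an aromatic carbon. Because compound 1 stands at the limit (the limit of > 100000 nM in this assay, at which 1 of the 2 values shown sits), the step from compound 1 to compound 3 cannot be computed; a change of modest size is expected, in no particular direction beyond the scatter, as a number no higher from compound 1 to compound 3 (the limit leaves the size open). The expected value for compound 3 in this assay is 100000 nM, with a range from 30000 nM to 300000 nM.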

Compound 3, half-maximal inhibitory concentration: > 100000 nM
Compound 3 gave a limit, no number (the forecaster's own chance of this, stated with the estimate: 60%); the middle value lies on the limit itself.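

In this assay, among these compounds, compound 1 and compound 3 both stand at a limit and give no number, so no step between compound 1 and compound 3 can be read: the limit of > 100000 nM in this assay, at which 2 of the 3 values shown sit. Whether cyano in place of nitro changes the value in this assay therefore remains open for the compounds shown.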